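Notes on methoxy in place of methyl across four compounds

This account rests on a few compounds, and the source may have more. Where it says the series, first, only, none or still open, it means among the compounds named here.

Compound 1 `Cc1ccc(-n2cc(NC(=O)c3cccc(NS(=O)(=O)c4ccc(Cl)cc4)c3)cn2)cc1` is measured in a functional assay on A549 cells (Homo sapiens) for inhibition, read by MTT assay, with a stated time of 48 h (on this read-out lower numbers stand for stronger inhibition and higher numbers for weaker inhibition), and gives 15600 nM. Compound 2 `COc1ccc(-n2cc(NC(=O)c3cccc(NS(=O)(=O)c4ccc(Cl)cc4)c3)cn2)cc1` carries methoxy in place of methyl on an aromatic carbon and in this assay compound 2 gives 29700 nM; the step is a 1.9-fold higher number from compound 1 to compound 2 (0.28 log units; within the scatter). Compound 3 `Cc1ccc(-n2cc(NC(=O)c3ccc(NS(=O)(=O)c4ccccc4)cc3)cn2)cc1` has a different core; the difference between the two cores is not broken down here. In this assay compound 3 gives 54700 nM, a number within the scatter of compound 2 and beyond the scatter relative to compound 1. Compound 4 `COc1ccc(-n2cc(NC(=O)c3ccc(NS(=O)(=O)c4ccccc4)cc3)cn2)cc1` is not yet measured and carries methoxy in place of methyl on an aromatic carbon, the same change as that from compound 1 to compound 2, at a place described in identical words. For compound 4 the expected step is a 1.7-fold higher number from compound 3 to compound 4 (0.24 log units; within the scatter), resting on the earlier step of a 1.9-fold higher number from compound 1 to compound 2 (0.28 log units; within the scatter) applied to compound 3. Compound 4 is therefore estimated at 95000 nM, between 45000 nM and 200000 nM.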

Compound 4, half-maximal inhibitory concentration: 85800 nM
Compound 4: the middle estimate sits 1.1-fold (0.04 log units) above what was measured; the measured number falls inside the stated range.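

In this assay, methoxy in place of methyl on an aromatic carbon gives a 1.6-fold higher number from compound 3 to compound 4 (0.20 log units; within the scatter). Set beside the step on the other core, the two agree: the same change on two cores in this assay, a 1.9-fold higher number (0.28 log units; within the scatter) from compound 1 to compound 2 and a 1.6-fold higher number (0.20 log units; within the scatter) from compound 3 to compound 4, 1.2-fold (0.08 log units) apart, within the scatter of two such steps. So the change carries from the core of compound 1 to the core of compound 3 without a detectable difference, but each step lies within the scatter, so neither shows that the change itself moves the number, and two cores say nothing about other cores in the series.

Open, on these data alone, is how other groups at this place behave on either core, such as an amine, a carboxylic acid or a longer chain like ethoxy. Also open, as far as these compounds go, is whether any such group gives a step beyond the scatter and whether that step would carry between these two cores.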